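The source may hold more compounds than are shown below. What is called first, only, known or untested is meant among the compounds shown, and "the series" means these compounds.

Measured in a functional assay on V79 cells (Cricetulus griseus) for cytotoxicity, read by colony formation; on this read-out higher numbers stand for weaker inhibition and lower numbers for stronger inhibition:
- compound 1 `O=C(O)c1cn(C2CC2)c2cc(N3CCCC3)c(F)cc2c1=O`: 38 ug/mL
- compound 2 `O=C(O)c1cn(C2CC2)c2c(F)c(N3CCCC3)c(F)cc2c1=O`: 120 ug/mL

Of these two numbers, compound 2 at 120 ug/mL is the higher. Compound 3 `O=C(O)c1cn(C2CC2)c2c(Cl)c(N3CCCC3)c(F)cc2c1=O`, not yet measured, differs from it by chloro in place of fluoro on an aromatic carbon. For the measured compounds named here, the only measured step that bears on this is a 3.2-fold higher number from compound 1 to compound 2 (0.50 log units; beyond the scatter), fluoro in place of hydrogen. It is modest and involves no chloro, so it sets only a rough scale. No change beyond the scatter is expected in this assay, and the estimated step is a 1.2-fold lower number from compound 2 to compound 3 (0.08 log units; within the scatter). For compound 3 the estimated value is 100 ug/mL, with an expected range of 45 ug/mL to 220 ug/mL.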

Compound 3, half-maximal inhibitory concentration: 150 ug/mL
Beside the measured number, compound 3's estimate is 1.5-fold (0.18 log units) below it; the measured number falls inside the stated range.
By their numbers in this assay, from the lowest: compound 1; then compounds 2 and 3 (each within the scatter of the next).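

In this assay chloro in place of fluoro on this aromatic carbon, ortho to a fused ring and to the pyrrolidin-1-yl group, gives a 1.3-fold higher number from compound 2 to compound 3 (0.10 log units; within the scatter) and so does not separate the two halogens. Chloro in place of hydrogen gives a 3.9-fold higher number from compound 1 to compound 3 (0.60 log units; beyond the scatter) on the same carbon, so the shift seen with a 3.2-fold higher number from compound 1 to compound 2 (0.50 log units; beyond the scatter) is not confined to fluoro. No measurement at hand gives a reason for this. From the compounds shown here alone, whether a methoxy group or an amine on this carbon would read like the halogens stays open. So does whether the halogen result holds with a piperazine in place of the pyrrolidin-1-yl group.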